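Exchanging morpholin-4-yl for pyrrolidin-1-yl on a carbonyl carbon

The source may hold more compounds than are shown below. What is called first, only, known or untested is meant among the compounds shown, and "the series" means these compounds.

- compound 1 `COc1ncc(-c2ccc3nccc(/C(C)=C/C(=O)N4CCN(C)CC4)c3c2)cc1NS(=O)(=O)c1ccc(F)cc1F` gives 140 nM
- compound 2 `COc1ncc(-c2ccc3nccc(/C(C)=C\C(=O)N4CCOCC4)c3c2)cc1NS(=O)(=O)c1ccc(F)cc1F` gives > 10000 nM (a limit of the assay)
- compound 3 `COc1ncc(-c2ccc3nccc(/C(C)=C/C(=O)N4CCOCC4)c3c2)cc1NS(=O)(=O)c1ccc(F)cc1F` gives 610 nM

In a functional assay on U-87MG ATCC cells for inhibition, with U-87 MG (Homo sapiens) as the target, read by sulforhodamine B assay, with a stated time of 72 h (a higher number here means a weaker inhibitor of growth, a lower number a stronger inhibitor of growth), compound 3 gives 610 nM, the higher of the two numerical values. Compound 2 reaches only a limit of the assay, > 10000 nM.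

Compound 4 `COc1ncc(-c2ccc3nccc(/C(C)=C/C(=O)N4CCCC4)c3c2)cc1NS(=O)(=O)c1ccc(F)cc1F` carries pyrrolidin-1-yl in place of morpholin-4-yl on a carbonyl carbon. Its double bond stays as drawn in compound 3, so the large step of an at least 16-fold lower number from compound 2 to compound 3 (1.21 log units; beyond the scatter) does not bear directly on this change.

Within the data shown here, the one measured exchange at this place with that double bond unchanged is modest: a 4.4-fold higher number from compound 1 to compound 3 (0.64 log units; beyond the scatter). Compound 1 , which lacks morpholin-4-yl, gives 140 nM, so a smaller step towards a lower number is expected. The expected change is a 1.7-fold lower number from compound 3 to compound 4 (0.24 log units; within the scatter).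

For compound 4 the estimate is 350 nM, with an expected range of 100 nM to 1200 nM.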

Compound 4, concentration for 50% growth inhibition: 390 nM
For compound 4 the middle estimate is 1.1-fold (0.05 log units) below the measured one; measured number inside the range.
By their numbers in this assay, from the lowest: compound 1; then compounds 4 and 3 (each within the scatter of the next). At a limit, above all of these: compound 2.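

In this assay, exchanging morpholin-4-yl for pyrrolidin-1-yl on the carbonyl carbon does not move the number beyond the scatter, with a 1.6-fold lower number from compound 3 to compound 4 (0.19 log units; within the scatter). The exchange from 4-methylpiperazin-1-yl to pyrrolidin-1-yl does, with a 2.8-fold higher number from compound 1 to compound 4 (0.44 log units; beyond the scatter), so among the three amides with the double bond drawn E, compound 1 alone stands apart from the other two. The step of an at least 25-fold lower number from compound 2 to compound 4 (1.40 log units; beyond the scatter) spans the double bond as well as the ring and starts from a limit of the assay: the limit of > 10000 nM in this assay, at which 1 of the 4 values shown sits.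

The compounds shown leave open whether piperidin-1-yl or an open-chain dimethylamino group on the carbonyl carbon would read with compound 1 or with compounds 3 and 4. They also leave open how 4-methylpiperazin-1-yl or pyrrolidin-1-yl reads with the double bond drawn Z.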